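A few compounds are considered here, and "the series" means these few. Any claim that something is new, unique, unknown or untested is made for them only; others in the source may bear on it.

Working notes on the series. In a functional assay on SW-620 cells (Homo sapiens) for antiproliferative activity, read by MTT assay, with a stated time of 72 h (on this read-out higher numbers stand for weaker inhibition and lower numbers for stronger inhibition), compound 1 `O=C1O/C(=C\Cn2cnc3c(F)nc(F)c(Cl)c32)C(OCc2ccccc2)=C1OCc1ccccc1` gives 55000 nM. Compound 2 `O=C1O/C(=C\Cn2cnc3ccnc(Cl)c32)C(OCc2ccccc2)=C1OCc1ccccc1` gives > 100000 nM, which is a limit and not a number, so it stands at the limit of > 100000 nM in this assay, at which 1 of the 2 values shown sits.

Compound 3 `O=C1O/C(=C\Cn2cnc3c(Cl)c(F)nc(F)c32)C(OCc2ccccc2)=C1OCc1ccccc1` differs from compound 2 at one place: a group of 12 heavy atoms (6 carbon, 3 nitrogen, 2 fluorine, 1 chlorine; one five-membered aromatic ring with 2 hetero atoms, one six-membered aromatic ring with 1 hetero atom) in place of a group of 10 heavy atoms (6 carbon, 3 nitrogen, 1 chlorine; one five-membered aromatic ring with 2 hetero atoms, one six-membered aromatic ring with 1 hetero atom), on a saturated chain carbon bound to a double-bonded chain carbon. Going by the values given here, the only measured step that bears on this change is an at least 1.8-fold higher number from compound 1 to compound 2 (0.25 log units; that floor lies within the scatter), which swaps groups of the same two counted kinds in the opposite direction. That step is only a floor and lies within the scatter, so it fixes no size for the change. Among the compounds with values here, the only numerical anchor is compound 1 at 55000 nM, and its group has the same count as the one entering compound 3.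

A modest move to a lower number in this assay is therefore expected, though it may not exceed the scatter. The expected change is an at least 1.6-fold lower number from compound 2 to compound 3 (0.22 log units; that floor lies within the scatter). For compound 3 the estimate is 60000 nM, with an expected range of 22000 nM to 100000 nM.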

Compound 3, half-maximal inhibitory concentration: 50000 nM
For compound 3 the middle estimate is 1.2-fold (0.08 log units) above the measured one, and the stated range covers the measured number.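

In this assay, moving the chlorine and the two fluorines to other places on the shared core, with the group's counted atoms unchanged, gives a 1.1-fold lower number from compound 1 to compound 3 (0.04 log units; within the scatter), so this rearrangement has no readable effect on the number at this position. The change from the group of 10 heavy atoms to the group of 12 heavy atoms now has a second reading, an at least 2.0-fold lower number from compound 2 to compound 3 (0.30 log units; that floor lies within the scatter), but it is again only a floor and fixes no size for the change. Compound 2 remains a limit and not a number: the limit of > 100000 nM in this assay, at which 1 of the 3 values shown sits.

The true size of the step between the two groups remains open, as does any effect beyond the scatter among these compounds. Also open, on these data alone, is how the number would respond to an amine in place of a fluorine, or to a free hydroxyl in place of a benzyloxy group.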